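A few compounds are considered here, and "the series" means these few. Any claim that something is new, unique, unknown or untested is made for them only; others in the source may bear on it.

Values from an ADME assay (liver) for metabolic stability, with Liver microsome (Rattus norvegicus) as the target, using microsomes (on this read-out higher numbers stand for fast clearance and lower numbers for slow clearance), for the measured compounds:
- compound 1 `O=c1[nH]c2ccc(-c3nnc(NCc4ccccc4)o3)cc2o1` gives 30 mL.min-1.g-1
- compound 2 `O=C1Cc2cc(-c3nnc(NCc4ccccc4)o3)ccc2N1` gives < 14 mL.min-1.g-1
- compound 3 `Fc1ccccc1CNc1nnc(-c2c[nH]c3ncccc23)o1` gives 46 mL.min-1.g-1

Compound 3 (46 mL.min-1.g-1) stands level with compound 1 (30 mL.min-1.g-1) within the usual scatter, so these two numbers cannot be told apart. For compound 2 the result (< 14 mL.min-1.g-1) is a limit of the assay and not a number.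

Compound 4 `c1cnc2[nH]cc(-c3nnc(NCc4ccncc4)o3)c2c1` has pyridin-4-yl in place of 2-fluorophenyl on a saturated chain carbon bound to a nitrogen on an aromatic ring. Among the measured compounds shown here, no measured pair of compounds shows a change of this kind, so the expectation rests on the structural change alone: a ring of carbon only gives way to a ring with a hetero atom. A modest drop in this assay is expected, estimated as (a 1.8-fold lower number from compound 3 to compound 4 (0.25 log units; within the scatter)) and possibly no larger than the scatter. Compound 4 is expected at 26 mL.min-1.g-1 with an estimated range of 14 mL.min-1.g-1 to 50 mL.min-1.g-1 for the measurement.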

Compound 4, intrinsic clearance in microsomes: 37 mL.min-1.g-1
Compound 4: the middle estimate sits 1.4-fold (0.15 log units) below what was measured, within the range that was stated.
By their numbers in this assay, from the lowest: compounds 1, 4 and 3 (each within the scatter of the next). At a limit, below all of these: compound 2.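

Among the compounds shown here, this is the first pair here that differs in one place only, so a change on a saturated chain carbon bound to a nitrogen on an aromatic ring can now be read directly in this assay. Pyridin-4-yl in place of 2-fluorophenyl gives a 1.2-fold lower number from compound 3 to compound 4 (0.09 log units; within the scatter), so replacing a ring of carbon only with a ring holding a hetero atom causes no change that can be told from the scatter in this pair. Nothing shown explains why these two compounds read alike.

On these data alone, it remains open whether a phenyl ring carrying an amine or a carboxylic acid would also read alike at this place, or whether a longer chain leading to the pyridin-4-yl ring would. As far as these compounds go, it is also open whether the same swap would give a similar result on the core of compound 1.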